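The source may report more compounds than this note shows. Statements on the series, on what has been measured and on what is new or still open speak of the compounds shown alone.

In a physicochemical assay for solubility, using potentiometric titration (on this read-out lower numbers stand for lower solubility and higher numbers for higher solubility), compound 1 `Fc1ccc(-c2nc(-c3ccc4nc[nH]c4c3)no2)cc1` gives 66900 nM, compound 2 `Fc1ccc(-c2nc(-c3ccc(-c4ccccc4)cc3)no2)cc1F` gives 16000 nM and compound 3 `Fc1ccc(-c2nc(-c3ccc(Br)cc3)no2)cc1F` gives 77000 nM. Compound 3 thus sits at the top of these numbers together with compound 1, the two lying within the scatter of each other, while compound 2 stands clearly lower.

Next in line is compound 4 `Cc1ccc(-c2noc(-c3ccc(F)c(F)c3)n2)cc1`, with methyl in place of bromo on an aromatic carbon, para to a large group: methyl in place of bromo on an aromatic carbon.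

Going by the values given here, only one measured step touches this place: a 4.8-fold higher number from compound 2 to compound 3 (0.68 log units; beyond the scatter), a modest step with bromo in place of phenyl on an aromatic carbon. It shows that a swap here can move the number beyond the scatter. It does not size the present swap, though, since phenyl takes no part in it. Among the compounds with values here, no measured step involves methyl, so the data give no direction for the change.

With so little to go on, no shift beyond the scatter is expected in this assay. The estimated change is a 1.0-fold higher number from compound 3 to compound 4 (0.02 log units; within the scatter), and this remains a default expectation, not a trend. For compound 4 the expected value is 80000 nM, with an estimated range of 35000 nM to 170000 nM.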

Compound 4, solubility: 35000 nM
Compound 4: middle estimate off by 2.3-fold (0.36 log units), on the high side; low and high end bracket the measured number.
By their numbers in this assay, from the lowest: compound 2; then compounds 4, 1 and 3 (each within the scatter of the next, the first and the last beyond it).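

In this assay, the swap of bromo for methyl on this aromatic carbon moves the number by itself (a 2.2-fold lower number from compound 3 to compound 4 (0.34 log units; beyond the scatter)), so this place responds to an exchange that does not involve phenyl, which the earlier step could not show. Methyl in place of phenyl also shifts the number (a 2.2-fold higher number from compound 2 to compound 4 (0.34 log units; beyond the scatter)), and together with the earlier step (a 4.8-fold higher number from compound 2 to compound 3 (0.68 log units; beyond the scatter)) this ranks the three groups at this place, from the lowest number: phenyl, methyl, bromo, with each step beyond the scatter and compound 4 lying between compound 2 and compound 3. Nothing at hand accounts for this order.

As far as these compounds go, how an amine, a carboxylic acid or a longer alkyl chain would rank against these three groups at this place remains open. From the compounds shown here alone, compounds 2, 3 and 4 share everything outside this place, so it also remains open whether these steps would keep their size and direction on a different remainder of the molecule.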